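A few compounds are considered here, and "the series" means these few. Any claim that something is new, unique, unknown or untested is made for them only; others in the source may bear on it.

Compound 2 `O=C(c1cccc(C(F)(F)F)c1)N(/N=N/c1ccc([N+](=O)[O-])cc1C(F)(F)F)c1ccc([N+](=O)[O-])cc1C(F)(F)F` gives 750 nM in a functional assay on HeLa cells (Homo sapiens) for cytotoxicity, read by MTT assay, with a stated time of 72 h; a higher number here means a weaker inhibitor, a lower number a stronger inhibitor. Going by the values given here, of the two numbers measured so far, that of compound 2 is the higher, but its only neighbour, compound 1 `O=C(c1ccccc1)N(/N=N/c1ccc([N+](=O)[O-])cc1C(F)(F)F)c1ccc([N+](=O)[O-])cc1C(F)(F)F`, gives 600 nM in this assay, and the step of a 1.3-fold higher number from compound 1 to compound 2 (0.10 log units; within the scatter) lies within the scatter, so the two compounds cannot be told apart on these numbers.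

Compound 3 `O=C(c1cccc(F)c1)N(/N=N/c1ccc([N+](=O)[O-])cc1C(F)(F)F)c1ccc([N+](=O)[O-])cc1C(F)(F)F` differs from compound 2 by fluoro in place of trifluoromethyl on an aromatic carbon. Among the compounds with values here, the only measured step that touches this position is the one in which trifluoromethyl replaced hydrogen, a 1.3-fold higher number from compound 1 to compound 2 (0.10 log units; within the scatter), and it stayed within the scatter. Taking the change back part of the way, to fluoro, is therefore expected to move the number by no more than that, in no direction that can be read: the expected step is a 1.2-fold lower number from compound 2 to compound 3 (0.06 log units; within the scatter). Compound 3 is estimated at 650 nM in this assay, with a range from 350 nM to 1200 nM.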

Compound 3, half-maximal inhibitory concentration: 880 nM
Estimate against measurement, compound 3: 1.4-fold (0.13 log units) below, within the range that was stated.
By their numbers in this assay, from the lowest: compounds 1, 2 and 3 (each within the scatter of the next).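

In this assay, fluoro at this position gives a result no more separable than trifluoromethyl did: the exchange of the two groups reads a 1.2-fold higher number from compound 2 to compound 3 (0.07 log units; within the scatter), and the exchange of hydrogen for fluoro reads a 1.5-fold higher number from compound 1 to compound 3 (0.17 log units; within the scatter). Both steps lie within the scatter, so hydrogen, fluoro and trifluoromethyl on this aromatic carbon, meta to a large group, cannot be told apart in these three compounds. The position has thus now accepted three different substituents with no readable shift in the number, and nothing available explains this.

On these data alone, whether an amine or a carboxylic acid on this carbon would shift the number stays open. So does whether a longer chain here would do so, since all three compounds carry only hydrogen or a small fluorinated group.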